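From sec-butyl to 2-methoxyethyl on the aromatic oxygen

The source may report more compounds than this note shows. Statements on the series, on what has been measured and on what is new or still open speak of the compounds shown alone.

Compound 1 `COc1cc(OC)c2c(c1)C(C(O)c1ccc(O)cc1)OC2=O` opens the series. In a functional assay on RAW264.7 cells (Mus musculus) for inhibition, read by Griess assay, with stated times of 1 h and 24 h (on this read-out higher numbers stand for weaker inhibition and lower numbers for stronger inhibition), compound 1 gives > 10000 nM, which is a limit of the assay and not a number. In this assay compound 2 `CCC(C)Oc1ccc(C(O)C2OC(=O)c3c(OC)cc(OC)cc32)cc1` gives > 10000 nM, again a limit and not a number. Going by the values given here, compound 2 therefore has no measured number, and the only other value beside it is also a limit. Both results stand at the limit of > 10000 nM in this assay, at which 2 of the 2 values shown sit.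

Compound 3 `COCCOc1ccc(C(O)C2OC(=O)c3c(OC)cc(OC)cc32)cc1` comes next. The change is 2-methoxyethyl in place of sec-butyl on an oxygen on an aromatic ring, with 2-methoxyethyl in place of sec-butyl on an oxygen on an aromatic ring. Among the compounds with values here, only one measured step bears on it, at the same oxygen: a step that the two limits leave unreadable from compound 1 to compound 2. That step has no readable size, so it offers no magnitude or direction to carry forward. No step beyond the scatter is expected in this assay, and another limit is the likeliest report. The expected change is a step that the limit leaves unreadable from compound 2 to compound 3. The estimate for compound 3 is 12000 nM, with an expected range of 5000 nM to 30000 nM.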

Compound 3, half-maximal inhibitory concentration: > 10000 nM
Compound 3 ended at the assay's limit; the forecaster's own chance of this, stated with the estimate: 80%; the middle value does not contradict the limit.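

Compound 1, compound 2 and compound 3 all end at a limit in this assay, not at a number, so no step among them can be read: the limit of > 10000 nM in this assay, at which 3 of the 3 values shown sit.

The compounds shown leave open whether hydrogen, sec-butyl and 2-methoxyethyl on the aromatic oxygen differ at all in this assay, and if so, in which direction and by how much.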